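From Chloro to Methyl on a Shared Core

The source may hold more compounds than are shown below. What is called first, only, known or untested is meant among the compounds shown, and "the series" means these compounds.

In a functional assay on NCI-H460 cells (Homo sapiens) for cytotoxicity, read by MTT assay, with a stated time of 24 h (a lower number here means a stronger inhibitor, a higher number a weaker inhibitor), compound 1 `O=Cc1cc2ccccc2n(Cc2ccccc2)c1=O` gives > 100000 nM, which is a limit of the assay and not a number. Compound 2 `C#CCn1c(=O)c(C=O)cc2cc(Cl)ccc21` gives > 100000 nM, which is also a limit. Within the data shown here, compound 2 therefore has no exact place on the scale, and the only evidence so far is the limit of > 100000 nM in this assay, at which 2 of the 2 values shown sit.

Compound 3 `C#CCn1c(=O)c(C=O)cc2cc(C)ccc21` keeps the shared core of compound 2 but carries methyl in place of chloro on an aromatic carbon. Among the measured compounds shown here, no measured pair yet shows what this swap does in this assay. With compound 2 at its limit of > 100000 nM, no change beyond the usual scatter is expected, and compound 3 may well return only a limit too. The expected change is a number no higher from compound 2 to compound 3 (the limit leaves the size open). Compound 3 is estimated at 100000 nM, with an expected range from 40000 nM to 200000 nM.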

Compound 3, half-maximal inhibitory concentration: > 100000 nM
Compound 3 ended at the assay's limit; the forecaster's own chance of this, stated with the estimate: 80%; the middle value sits exactly at the limit.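

Compound 2 and compound 3 both stop at a limit of the assay instead of giving a number, so the swap of chloro for methyl between them cannot be read. The compounds shown leave open what change, if any, would give a measurable value in this assay.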